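This account rests on a few compounds, and the source may have more. Where it says the series, first, only, none or still open, it means among the compounds named here.

For the measured compounds named here, compound 2 `Cc1nc(S(C)(=O)=O)ccc1Oc1ncnc(OC2CCN(C(=O)OC3(C(F)(F)F)CCC3)CC2)c1F` stands highest of the two numbers so far in a functional assay on isolated protein for inhibition of Glucose-dependent insulinotropic receptor (Rattus norvegicus), read by HTRF and cAMP accumulation; on this read-out lower numbers stand for smaller maximal responses and higher numbers for larger maximal responses: compound 2 gives 82%, whereas compound 1 `Cc1nc(S(C)(=O)=O)ccc1Oc1ncnc(OC2CCN(C(=O)OC(C)F)CC2)c1F` gives 68%. Going by the values given here, the only step measured between them is a number 14 percentage points higher from compound 1 to compound 2 (beyond the scatter), and it concerns the same carbamate end of the shared core that is now being changed again. The third member of the series is compound 3 `Cc1nc(S(C)(=O)=O)ccc1Oc1ncnc(OC2CCN(C(=O)SC3(C)CC3)CC2)c1F`, which is yet to be measured in this assay. Relative to compound 2 the difference is a group of 5 heavy atoms (4 carbon, 1 sulfur; one three-membered non-aromatic ring of carbon only) in place of a group of 9 heavy atoms (5 carbon, 1 oxygen, 3 fluorine; one four-membered non-aromatic ring of carbon only), on a carbonyl carbon.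

Among the compounds with values here, the one step that bears on this change, a number 14 percentage points higher from compound 1 to compound 2 (beyond the scatter), went upward when a larger fluorinated ring replaced a small open-chain group. Compound 3 moves back toward a smaller group and exchanges the oxygen for a sulfur, so that step gives only a loose guide, and its direction need not repeat. A single modest step allows no firm expectation of more than a modest movement either way.

On that footing, compound 3 is expected to lie at 73%, within a range of 58% to 88%. The step this estimate implies is a number 9 percentage points lower from compound 2 to compound 3 (within the scatter), expected to fall close to the scatter.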

Compound 3, largest response reached (reported as efficacy), in percent of the reference or control that the assay uses: 77%
Compound 3: middle estimate off by 4 percentage points, on the low side, within the range that was stated.
By their numbers in this assay, from the lowest: compounds 1, 3 and 2 (each within the scatter of the next, the first and the last beyond it).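

On a carbonyl carbon whose other neighbours are an amide-type nitrogen in a ring, in this assay, replacing the group of 9 heavy atoms with its four-membered ring by the sulfur-bearing group of 5 heavy atoms with its three-membered ring gives a number 5 percentage points lower from compound 2 to compound 3 (within the scatter), so this read-out does not separate the two groups. For the compounds shown here, the same sulfur-bearing group, set against the open-chain group of compound 1, gives a number 9 percentage points higher from compound 1 to compound 3 (within the scatter), so compound 3 is separated from neither of the earlier compounds, even though the earlier a number 14 percentage points higher from compound 1 to compound 2 (beyond the scatter) did separate those two from each other. No measurement offered here accounts for this behaviour at the position.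

On these data alone, compound 3 differs from compound 2 in its ring and its sulfur at once, so what each change contributes on its own remains open. Also open, as far as these compounds go, is how an amine or a tert-butyl group on the same carbonyl carbon would compare with these three compounds.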